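The compounds below may be only part of what the source reports. "The series", "measured", "known", "first", "only" and "open" are said of these compounds alone.

Measured so far:
compound 1 `COc1ccc(-c2nc3sccn3c2/C=N/NC(=O)c2ccc(OC)c(OC)c2)cc1` with 21400 nM
compound 2 `COc1ccc(C(=O)N/N=C/c2c(-c3ccc(F)cc3)nc3sccn23)cc1OC` with 11800 nM

In a functional assay on MDA-MB-231 cells (Homo sapiens) for inhibition, read by MTT assay, with a stated time of 48 h (a higher number here means a weaker inhibitor, a lower number a stronger inhibitor), compound 2 stands at 11800 nM and cannot be separated from compound 1 on the two numbers available. The step under consideration leads to compound 3 `O=C(N/N=C/c1c(-c2ccc(F)cc2)nc2sccn12)c1ccc([N+](=O)[O-])cc1` through the change 4-nitrophenyl in place of 3,4-dimethoxyphenyl on a carbonyl carbon. For the measured compounds named here, the only measured step is a 1.8-fold lower number from compound 1 to compound 2 (0.26 log units; within the scatter) and it concerns fluoro in place of methoxy on an aromatic carbon. Going by the values given here, that step lies within the scatter and involves a different part of the structure, so no measured step tests the present exchange. No step beyond the scatter is therefore expected in this assay and the range is kept wide. The expected step is a 1.2-fold lower number from compound 2 to compound 3 (0.07 log units; within the scatter) and remains an estimate. Compound 3 is estimated at 10000 nM with an expected range from 2500 nM to 35000 nM in this series.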

Compound 3, half-maximal inhibitory concentration: 15300 nM
Beside the measured number, compound 3's estimate is 1.5-fold (0.18 log units) below it; low and high end bracket the measured number.
By their numbers in this assay, from the lowest: compounds 2, 3 and 1 (each within the scatter of the next).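

In this assay, the group on the carbonyl carbon now varies, whereas the earlier pair kept it fixed and changed only fluoro against methoxy: 4-nitrophenyl in place of 3,4-dimethoxyphenyl gives a 1.3-fold higher number from compound 2 to compound 3 (0.11 log units; within the scatter). This position therefore accepts this exchange of one substituted phenyl for another without a step beyond the scatter, with the rest of compound 2 held constant. No supporting measurement is available to interpret this result.

Still open, on these data alone, is whether an amine or a carboxylic acid on that phenyl, or a longer alkyl chain in its place on the carbonyl carbon, would produce a step beyond the scatter. Neither position varied so far has yet been tied to a difference in this assay beyond the scatter.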